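A few compounds are considered here, and "the series" means these few. Any claim that something is new, unique, unknown or untested is made for them only; others in the source may bear on it.

In a functional assay on K562 cells (Homo sapiens) for antiproliferative activity, with a stated time of 72 h (on this read-out higher numbers stand for weaker inhibition and lower numbers for stronger inhibition), compound 1 `OC[C@H]1O[C@@H](n2cnc3c(NCc4ccc(Br)cc4)ncnc32)[C@H](O)[C@@H]1O` gives 68200 nM, while compound 2 `OC[C@H]1O[C@@H](n2cnc3c(NCc4ccc(F)cc4Cl)ncnc32)[C@H](O)[C@@H]1O` gives 15600 nM, the lower of the two numbers. Among the measured compounds shown here, the only measured step, a 4.4-fold lower number from compound 1 to compound 2 (0.64 log units; beyond the scatter), is modest and lies beyond the scatter. Compound 3 `OC[C@H]1O[C@@H](n2cnc3c(NCc4cccc(C(F)(F)F)c4)ncnc32)[C@H](O)[C@@H]1O` keeps the shared core but differs from compound 2 in one place: 3-(trifluoromethyl)phenyl in place of 2-chloro-4-fluorophenyl on a saturated chain carbon bound to a nitrogen on an aromatic ring. It thus has 3-(trifluoromethyl)phenyl in place of 2-chloro-4-fluorophenyl. For the measured compounds named here, the measured step shows that exchanging this group can shift the number, but no measured compound carries 3-(trifluoromethyl)phenyl, so it gives only a rough size. As compound 2 is the lower of just two numbers, a small rise no larger than that step is expected, rather than a further fall. The expected change is a 1.9-fold higher number from compound 2 to compound 3 (0.28 log units; within the scatter). For compound 3, the estimated value is 30000 nM, with an expected range of 9000 nM to 80000 nM.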

Compound 3, half-maximal inhibitory concentration: > 166000 nM
Compound 3: no number, only a limit; the forecaster's own chance of this, stated with the estimate: 15%; at least 5.5-fold (0.74 log units) between middle value and limit.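

In this assay compound 3 gives > 166000 nM, which is a limit and not a number, and it alone stands there: the limit of > 166000 nM in this assay, at which 1 of the 3 values shown sits. Even so, 3-(trifluoromethyl)phenyl in place of 2-chloro-4-fluorophenyl gives an at least 10-fold higher number from compound 2 to compound 3 (1.02 log units; beyond the scatter), so on a saturated chain carbon bound to a nitrogen on an aromatic ring the number can move further than the one modest earlier step showed. Against the remaining compound, 3-(trifluoromethyl)phenyl in place of 4-bromophenyl gives an at least 2.4-fold higher number from compound 1 to compound 3 (0.38 log units; beyond the scatter), which places compound 3 as the weakest of the three and compound 2 as the strongest.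

The compounds shown leave open how 4-(trifluoromethyl)phenyl, 3-bromophenyl or an aminophenyl group would read at this place. The effect of the substituent and that of its position on the ring therefore cannot yet be told apart.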